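From Ester to Amide: An Expected Cytotoxicity Reading

The source may hold more compounds than are shown below. What is called first, only, known or untested is meant among the compounds shown, and "the series" means these compounds.

Measured so far:
compound 1 `CCCCCC[C@H]1C[C@@H](O)[C@@H](O)C1` — 110000 nM
compound 2 `CCOC(=O)/C=C/[C@H]1C[C@@H](O)[C@@H](O)C1` — > 350000 nM

Of the compounds shown here, two have been tested in an ADME assay on S2 cells (Drosophila melanogaster) for cytotoxicity, read by MTT assay; on this read-out higher numbers stand for an effect only at larger amounts of compound and lower numbers for an effect already at smaller amounts. Compound 1 gives 110000 nM. Compound 2 gives > 350000 nM, which is a limit of the assay rather than a number. On the numbers shown, compound 2 stands at the limit of > 350000 nM in this assay, at which 1 of the 2 values shown sits.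

The next compound, compound 3 `NC(=O)/C=C/[C@H]1C[C@@H](O)[C@@H](O)C1`, differs from compound 2 in one place: amino in place of ethoxy on a carbonyl carbon. Going by the values given here, no measured pair of compounds differs in only one place, so the size of such a step in this assay cannot be read from these data. In this assay the expected step is a step that the limit leaves unreadable from compound 2 to compound 3, no change beyond the scatter, with the result most likely reported again as a limit. Compound 3 is expected to give about 400000 nM, between 150000 nM and 1000000 nM.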

Compound 3, half-maximal effective concentration: > 250000 nM
Compound 3 gave a limit, no number (the forecaster's own chance of this, stated with the estimate: 70%); the middle value does not contradict the limit.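

Compound 2 and compound 3 each gave only a limit, not a number, in this assay, and the step from ethoxy to amino cannot be read. The compounds shown leave open how far, if at all, this change on the carbonyl carbon moves the reading in this assay.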